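This account rests on a few compounds, and the source may have more. Where it says the series, first, only, none or still open, it means among the compounds named here.

Compounds measured so far:
compound 1 `C=CCN(C)c1nc(N)nc2c1ncn2[C@H]1C[C@H](N=[N+]=[N-])[C@@H](CO)O1`: 27000 nM
compound 2 `[N-]=[N+]=N[C@H]1C[C@H](n2cnc3c(NCCO)nc(N)nc32)O[C@@H]1CO`: > 100000 nM

In an ADME assay on CCRF-CEM cells (Homo sapiens) for cytotoxicity, with a stated time of 5 days (on this read-out higher numbers stand for weaker inhibition and lower numbers for stronger inhibition), compound 1 gives 27000 nM. Compound 2 reaches only a limit of the assay, > 100000 nM. Compound 3 `CC(C)(CO)Nc1nc(N)nc2c1ncn2[C@H]1C[C@H](N=[N+]=[N-])[C@@H](CO)O1` differs from compound 2 by 1-(hydroxymethyl)-1-methylethyl in place of 2-hydroxyethyl on a nitrogen on an aromatic ring. For the measured compounds named here, the only measured step, an at least 3.7-fold higher number from compound 1 to compound 2 (0.56 log units; beyond the scatter), concerns a different exchange and does not bear on this one; compound 2 stands at the limit of > 100000 nM in this assay, at which 1 of the 2 values shown sits. Going by the values given here, with no matching step, compound 3 is expected to change little, the expected step being a number no higher from compound 2 to compound 3 (the limit leaves the size open). The estimate for compound 3 is 100000 nM, ranging from 30000 nM to 300000 nM.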

Compound 3, half-maximal inhibitory concentration: > 100000 nM
Compound 3: a limit, no number; the forecaster's own chance of this, stated with the estimate: 60%; the middle value lies on the limit itself.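

In this assay, a second hydroxyl-bearing group on this position gives the same kind of result as the first: an at least 3.7-fold higher number from compound 1 to compound 3 (0.56 log units; beyond the scatter). The branched 1-(hydroxymethyl)-1-methylethyl chain therefore also stands apart from allyl(methyl)amino. The step between compound 2 and compound 3 cannot be read, and the assay limit hides any difference between these two chains: the limit of > 100000 nM in this assay, at which 2 of the 3 values shown sit.

The compounds shown leave open whether a carboxylic acid in place of the hydroxyl, or a longer chain, would give a number inside the limit.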